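Triazolyl to pyrimidinyl on the core: plasma protein binding

The source may hold more compounds than are shown below. What is called first, only, known or untested is meant among the compounds shown, and "the series" means these compounds.

Measured:
compound 1 `Cc1cc(-n2nccn2)cc(C(=O)NNS(=O)(=O)c2ccccc2)c1F` — 99.4%
compound 2 `C=CCOc1ccc(F)c(C(=O)NNS(=O)(=O)c2ccccc2)c1` — 98%

In an ADME assay on a cell-free system (plasma, Mus musculus) for protein binding, read by LC-MS, using ultracentrifugation, with a stated time of 4.2 h, tested at 1000 ng/mL, compound 1 gives 99.4%, the lowest unbound fraction of the two measured compounds; the nearest, compound 2, shows a higher unbound fraction at 98%, a gap beyond the scatter. Compound 3 `Cc1cc(-c2ncccn2)cc(C(=O)NNS(=O)(=O)c2ccccc2)c1F` is not yet measured. It differs from compound 1 by pyrimidin-2-yl in place of 2H-1,2,3-triazol-2-yl on an aromatic carbon. Going by the values given here, no measured pair isolates this change. The step from compound 1 to compound 3 is expected to be small, a 1.2-fold lower unbound fraction from compound 1 to compound 3 (0.08 log units; within the scatter), not beyond the scatter, with binding staying high. For compound 3 the estimate in this assay is 99.5%, range 98.8% to 99.8%.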

Compound 3, plasma protein binding: 99.4%
For compound 3 the middle estimate is 1.2-fold (0.08 log units) (unbound fraction) below the measured one; low and high end bracket the measured number.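

In this assay, going by these compounds alone, the exchange of 2H-1,2,3-triazol-2-yl for pyrimidin-2-yl on this aromatic carbon shows no change at the digits printed from compound 1 to compound 3 (within the scatter) as the first readable step. At this position, a six-membered aromatic ring with 2 hetero atoms therefore stands in for a five-membered one with 3 hetero atoms without a step beyond the scatter. No available evidence bears on the reason for this result. Still open, as far as these compounds go, is whether an amine or a carboxylic acid on this carbon would move binding beyond the scatter.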